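Acetamido to (ethylcarbamoyl)amino on the shared core

The compounds below may be only part of what the source reports. "The series", "measured", "known", "first", "only" and "open" are said of these compounds alone.

Of the compounds shown here, three carry the numbers so far. Compound 1 `CC(C)c1ccccc1OS(=O)(=O)c1cccc(NC(=O)CCCl)c1` gives 12000 nM in a functional assay on MCF7 cells (Homo sapiens) for antiproliferative activity, read by sulforhodamine B assay, with a stated time of 48 h; a lower number here means a stronger inhibitor, a higher number a weaker inhibitor. Compound 2 `CC(=O)Nc1ccc(S(=O)(=O)Oc2ccccc2C(C)C)cc1` gives 16000 nM in this assay, and compound 3 `CC(=O)Nc1ccc(S(=O)(=O)Oc2ccccc2I)cc1` gives 27000 nM. Within the data shown here, the only single-point step measured is a 1.7-fold higher number from compound 2 to compound 3 (0.23 log units; within the scatter). Compound 3 thus stands highest of the three numbers; compound 2 lies nearest to it, within the scatter, and compound 1 furthest, beyond the scatter.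

Compound 4 `CCNC(=O)Nc1ccc(S(=O)(=O)Oc2ccccc2I)cc1` differs from compound 3 in one place: ethylamino in place of methyl on a carbonyl carbon. Read one bond further out, the acetamido of compound 3 becomes the (ethylcarbamoyl)amino of compound 4. Among the measured compounds shown here, no measured step touches this part of the series. For the measured compounds named here, the one step available, a 1.7-fold higher number from compound 2 to compound 3 (0.23 log units; within the scatter), concerns the group on the aromatic carbon and says nothing about the carbonyl side. Going by the values given here, compound 1 and compound 2 differ at the acyl group but also in a second place, so no single step connects them; compound 1 gives 12000 nM and compound 2 gives 16000 nM, which shows no separation beyond the scatter. With nothing to lean on, the expectation for compound 4 is a step of no change at the digits printed from compound 3 to compound 4 (within the scatter), that is none beyond the scatter. Compound 4 is therefore estimated at 27000 nM, with a range from 10000 nM to 70000 nM.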

Compound 4, half-maximal inhibitory concentration: 1100 nM
Beside the measured number, compound 4's estimate is 25-fold (1.39 log units) above it; the whole stated range lies above it.
By their numbers in this assay, from the lowest: compound 4; then compounds 1, 2 and 3 (each within the scatter of the next, the first and the last beyond it).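

In this assay, among these compounds, the carbonyl carbon is the first place where a single change moves the number beyond the scatter: acetamido to (ethylcarbamoyl)amino gives a 25-fold lower number from compound 3 to compound 4 (1.39 log units; beyond the scatter). Among the compounds shown here, the only earlier single-place step, a 1.7-fold higher number from compound 2 to compound 3 (0.23 log units; within the scatter), concerned the group on the aromatic carbon and stayed within the scatter, so on these two steps the carbonyl side responds and the aromatic carbon does not yet, although two steps establish no pattern. The change swaps methyl for ethylamino, adding heavy atoms and a hydrogen-bond donor at once, and no measurement shown bears on why the number falls at this position.

The compounds shown do not separate the entering nitrogen from the added carbons: a propyl group on the carbonyl carbon would isolate the chain, while methylamino or butylamino would show how the number follows chain length with the nitrogen kept. Also open, as far as these compounds go, is whether the same change carries over to the isopropyl partner, compound 2, or depends on the iodo group present in compound 3 and compound 4.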